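Swapping Cyclopentyl for Isopropyl on Compound 1

The source may hold more compounds than are shown below. What is called first, only, known or untested is meant among the compounds shown, and "the series" means these compounds.

Among the measured compounds shown here, compound 1 `N=C(NC(=N)NC1CCCC1)Nc1ccc(C(F)(F)F)cc1` stands lowest of the three compounds measured so far in a functional assay on UMUC3 cells (Homo sapiens) for antiproliferative activity, read by MTT assay, with a stated time of 72 h (a lower number here means a stronger inhibitor, a higher number a weaker inhibitor), where compound 1 gives 3300 nM. Compound 2 `CC(C)NC(=N)NC(=N)Nc1ccc(F)c(F)c1` gives 25000 nM and compound 3 `CC(C)CNC(=N)NC(=N)Nc1ccc(F)cc1F` gives 17300 nM; both gaps to compound 1 lie beyond the scatter, so compound 1 is the strongest inhibitor of the three. Compound 4 `CC(C)NC(=N)NC(=N)Nc1ccc(C(F)(F)F)cc1` is not yet measured. It differs from compound 1 in one place: isopropyl in place of cyclopentyl on an amine nitrogen. For the measured compounds named here, no measured pair shows this change on its own, and compounds 2 and 3 differ from compound 1 elsewhere as well. A modest weakening is expected, with the step from compound 1 to compound 4 estimated as a 2.1-fold higher number from compound 1 to compound 4 (0.33 log units; beyond the scatter). Compound 4 is therefore expected to give about 7000 nM in this assay, within a range from 2500 nM to 20000 nM.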

Compound 4, half-maximal inhibitory concentration: 5200 nM
Beside the measured number, compound 4's estimate is 1.3-fold (0.13 log units) above it; the measured number falls inside the stated range.
By their numbers in this assay, from the lowest: compounds 1 and 4 (each within the scatter of the next); then compounds 3 and 2 (each within the scatter of the next).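

Isopropyl in place of cyclopentyl on an amine nitrogen gives a 1.6-fold higher number from compound 1 to compound 4 (0.20 log units; within the scatter) in this assay. This first single-change pair shows that, at this position, the cyclopentyl ring can give way to the open isopropyl group without a difference that stands clear of the scatter. No available evidence bears on this result.

The compounds shown leave open whether a longer chain, a cyclohexyl ring or a chain ending in an amine would behave alike here. They also leave open whether this change holds with a group other than trifluoromethyl on the core.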